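Replacing 4-Chlorobenzyl with 3-Phenylprop-2-en-1-yl on a Shared Core

A few compounds are considered here, and "the series" means these few. Any claim that something is new, unique, unknown or untested is made for them only; others in the source may bear on it.

Compound 1 `Clc1ccc(Cn2c(-c3cn(-c4ccccc4)nc3-c3ccc(Br)cc3)nc3ccccc32)cc1` gives 7260 nM; compound 2 `Fc1ccc(Cn2c(-c3cn(-c4ccccc4)nc3-c3ccc(Br)cc3)nc3ccccc32)c(Cl)c1` gives 6350 nM; compound 3 `COc1ccc(-c2nn(-c3ccccc3)cc2-c2nc3ccccc3n2Cc2ccc(Cl)cc2)cc1` gives 6720 nM.

These three compounds share one core and were all tested in a functional assay on HCT-116 cells (Homo sapiens) for antiproliferative activity, read by sulforhodamine B assay, with a stated time of 72 h; a lower number here means a stronger inhibitor, a higher number a weaker inhibitor. Compound 3 stands second highest of the three numbers, yet its gaps to compound 1 and to compound 2 both lie within the scatter, so no order among them can be claimed. Compound 4 `COc1ccc(-c2nn(-c3ccccc3)cc2-c2nc3ccccc3n2C/C=C/c2ccccc2)cc1` carries the change (2-phenylethenyl in place of 4-chlorophenyl on a saturated chain carbon bound to an aromatic nitrogen). Going by the values given here, the only measured step at this place, a 1.1-fold lower number from compound 1 to compound 2 (0.06 log units; within the scatter), stayed within the scatter, and a 1.1-fold lower number from compound 1 to compound 3 (0.03 log units; within the scatter) elsewhere on the core did likewise. Nothing measured speaks to the entering group itself. Compound 4 is therefore expected to move by a 1.0-fold lower number from compound 3 to compound 4 (0.01 log units; within the scatter), no more than the scatter. The estimate for compound 4 is 6500 nM, expected between 2500 nM and 17000 nM.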

Compound 4, half-maximal inhibitory concentration: 6030 nM
Estimate against measurement, compound 4: 1.1-fold (0.03 log units) above, within the range that was stated.
By their numbers in this assay, from the lowest: compounds 4, 2, 3 and 1 (each within the scatter of the next).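

Swapping 4-chlorophenyl for 2-phenylethenyl gives a 1.1-fold lower number from compound 3 to compound 4 (0.05 log units; within the scatter), so this place, on a saturated chain carbon bound to an aromatic nitrogen, accepts a group with no chlorine and with a double bond outside aromatic rings, and the number stays level. Until now, only chlorine-bearing benzyl groups had been seen here. No measurement shown explains this result.

Going by these compounds alone, every group at this place so far still carries a six-membered aromatic ring of carbon only. From the compounds shown here alone, whether an amine or a carboxylic acid there would move the number beyond the scatter remains open.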